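A few compounds are considered here, and "the series" means these few. Any claim that something is new, unique, unknown or untested is made for them only; others in the source may bear on it.

Among the compounds with values here, in an ADME assay on the whole organism (plasma) with Homo sapiens as the target (on this read-out higher numbers stand for a longer-lived compound and lower numbers for a shorter-lived compound), two compounds carry numbers so far. Compound 1 `CC(=O)Oc1ccccc1C(=O)OCC(=O)N(C1CCCCC1)C1CCCCC1` gives 0.345 h as its half-life and compound 2 `CC(=O)OCOC(=O)c1ccccc1OC(C)=O` gives 0.03 h as its half-life, which makes compound 2 the lower of the two, with a gap beyond the scatter.

The next structure is compound 3 `COC(=O)c1ccccc1OC(C)=O` and the change from compound 2 is hydrogen in place of acetoxy on a saturated chain carbon bound to an oxygen next to a carbonyl group with hydrogen in place of acetoxy on a saturated chain carbon bound to an oxygen next to a carbonyl group. Within the data shown here, no measured pair shows this change, so its size cannot be read directly from the data.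

A rise beyond the scatter is expected, with compound 3 placed closer to compound 1 at 0.345 h on the half-life scale. The estimated step is a 6.7-fold higher number from compound 2 to compound 3 (0.82 log units; beyond the scatter) in this assay as a working figure. Compound 3 is expected at 0.2 h with an estimated range from 0.05 h to 0.8 h in this read-out.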

Compound 3, half-life: 0.0533 h
For compound 3 the middle estimate is 3.8-fold (0.57 log units) above the measured one, and the stated range covers the measured number.
By their numbers in this assay, from the lowest: compounds 2 and 3 (each within the scatter of the next); then compound 1.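

In this assay, within the data shown here, the only pair differing in one place gives a first direct reading of this change (a 1.8-fold higher number from compound 2 to compound 3 (0.25 log units; within the scatter)). Hydrogen in place of acetoxy, on a saturated chain carbon bound to an oxygen next to a carbonyl group, thus stays within the scatter, and acetoxymethoxy and methoxy cannot be told apart on this read-out. No available evidence bears on this result.

The compounds shown leave open whether an amine, a carboxylic acid or a longer chain at this place would give a step beyond the scatter. Also open is what a single change would show for compound 1, which has no partner differing in one place among the compounds shown.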